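Extending the Long Chain: From Compound 2 to Compound 3

This account rests on a few compounds, and the source may have more. Where it says the series, first, only, none or still open, it means among the compounds named here.

Compound 1 `CCCCCCCCCCCCCCCCc1c(C)c(N(C)C)nc(C)c1O` and compound 2 `CCCCCCCCCCc1c(C)c(N(C)C)nc(C)c1O` share one core and differ only in chain length. In a functional assay on cells (Lymphocyte, Homo sapiens) for inhibition, read by flow cytometry, using a membrane potential dye, with a stated time of 16 h, tested at 100 nM (on this read-out lower numbers stand for a weaker effect and higher numbers for a stronger effect at the one concentration tested), compound 1 gives 62%, and compound 2 gives 60%. The step of a number 2 percentage points lower from compound 1 to compound 2 (within the scatter) left the read-out essentially unchanged, so compound 2 stands alongside compound 1, the two within the scatter of each other. Compound 3 `CCCCCCCCCCCCCCCCCCCc1c(C)c(N(C)C)nc(C)c1O` differs from compound 2 by nonyl in place of hydrogen on a saturated chain carbon, ten or more bonds along the chain from an aromatic carbon. Given the step of a number 2 percentage points lower from compound 1 to compound 2 (within the scatter), a further change in chain length is expected to move the read-out little. Compound 3 is therefore expected at 61%, between 46% and 76%. The expected step is a number 1 percentage points higher from compound 2 to compound 3 (within the scatter), within the scatter.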

Compound 3, a percentage reported as activity, at one concentration (the size of the read-out at that concentration, not a potency): 23%
For compound 3 the middle estimate is 38 percentage points above the measured one; the whole stated range lies above it.
By their numbers in this assay, from the lowest: compound 3; then compounds 2 and 1 (each within the scatter of the next).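

Until now, changing the chain length on the shared core had moved nothing beyond the scatter in this assay. The longest chain shows that this position does respond to the change, with a number 37 percentage points lower from compound 2 to compound 3 (beyond the scatter) and a number 39 percentage points lower from compound 1 to compound 3 (beyond the scatter), whereas compound 1 and compound 2 stay within the scatter of each other. Nothing available here bears on why the read-out falls at this chain length.

Left open is at which length beyond that of compound 1 the fall sets in. Also open, on these data alone, is how a chain as long as that of compound 3 would read if it ended in a carboxylic acid or an amine.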